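From Hydroxyphenyl to Pyridyl: Expected Potency of Compound 4

The source may hold more compounds than are shown below. What is called first, only, known or untested is meant among the compounds shown, and "the series" means these compounds.

Of the compounds shown here, three sharing one core have been tested in an assay on isolated protein for inhibition of acyl-CoA desaturase 1 (Rattus norvegicus); on this read-out higher numbers stand for weaker inhibition and lower numbers for stronger inhibition. Compound 1 `CS(=O)(=O)c1ccc2nc(-c3ccc(-c4ccccc4)cc3)[nH]c2c1` gives 20 nM. Compound 2 `CS(=O)(=O)c1ccc2nc(-c3ccc(-c4ccc(Cl)cc4)cc3)[nH]c2c1` reaches only the limit of the assay, > 20000 nM. Compound 3 `CS(=O)(=O)c1ccc2nc(-c3ccc(-c4ccccc4O)cc3)[nH]c2c1` gives 336 nM, the highest of the two numbers obtained so far; its nearest neighbour is compound 1, with a 17-fold higher number from compound 1 to compound 3 (1.23 log units; beyond the scatter). The other measured step, an at least 1000-fold higher number from compound 1 to compound 2 (3.00 log units; beyond the scatter), shows that a single added chloro on the outer ring pushes inhibition beyond the reach of the assay (the limit of > 20000 nM in this assay, at which 1 of the 3 values shown sits).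

Compound 4 `CS(=O)(=O)c1ccc2nc(-c3ccc(-c4ccccn4)cc3)[nH]c2c1` differs from compound 3 by pyridin-2-yl in place of 2-hydroxyphenyl on an aromatic carbon. For the measured compounds named here, the hydroxy group of compound 3 leaves, and a ring with one hetero atom enters; no measured step tests such a ring at this position. Going by the values given here, the removal of the hydroxy, whose addition gave a 17-fold higher number from compound 1 to compound 3 (1.23 log units; beyond the scatter), is the only guide, so the number is expected to fall moderately, a 3.4-fold lower number from compound 3 to compound 4 (0.53 log units; beyond the scatter), with wide uncertainty. Compound 4 is estimated at 100 nM, within 20 nM to 700 nM.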

Compound 4, half-maximal inhibitory concentration: 1710 nM
Beside the measured number, compound 4's estimate is 17-fold (1.23 log units) below it; the measured number lies above the stated range.
By their numbers in this assay, from the lowest: compound 1; then compound 3; then compound 4. At a limit, above all of these: compound 2.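

In this assay, replacing the phenyl of compound 1 with pyridin-2-yl, which swaps one ring carbon for nitrogen, gives an 86-fold higher number from compound 1 to compound 4 (1.93 log units; beyond the scatter), so even a change within the ring itself counts heavily at this place, para to a large group. Losing the hydroxy did not bring the number back towards that of compound 1, for the step is a 5.1-fold higher number from compound 3 to compound 4 (0.71 log units; beyond the scatter), and all three changes to the outer ring shown so far raise the number. Compound 2 stands at a limit rather than a true number, so an at least 11-fold lower number from compound 2 to compound 4 (1.06 log units; beyond the scatter) gives only a bound on that gap.

From the compounds shown here alone, whether a fluoro, a methoxy or an amine on the outer ring, or a thiophene in its place, would be tolerated remains open. No compound shown has a lower number than compound 1, at 20 nM.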